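Ring Expansion on the Amine Side of the Core

A few compounds are considered here, and "the series" means these few. Any claim that something is new, unique, unknown or untested is made for them only; others in the source may bear on it.

Compound 1 `COc1cc2ncnc(N3CCc4ccccc43)c2cc1NC(=O)C=C(C)C` gives 6390 nM
Compound 2 `COc1cc2ncnc(N3CCc4ccccc43)c2cc1NC(=O)/C=C/CN1CCN(C)CC1` gives 6430 nM
Compound 3 `COc1cc2ncnc(N3CCc4ccccc43)c2cc1NC(=O)/C=C/CN1CCC(CO)CC1` gives 2620 nM

These three compounds share a core and differ only in the amide side chain; all were tested in a functional assay on MCF7 cells (Homo sapiens) for antiproliferative activity, read by MTT assay, with a stated time of 72 h; on this read-out lower numbers stand for stronger inhibition and higher numbers for weaker inhibition. Compound 2 gives the top number of the three: compound 1 matches it a 1.0-fold higher number from compound 1 to compound 2 (0.00 log units; within the scatter), while compound 3 comes out lower a 2.5-fold lower number from compound 2 to compound 3 (0.39 log units; beyond the scatter), and also lower than compound 1 a 2.4-fold lower number from compound 1 to compound 3 (0.39 log units; beyond the scatter). Compound 4 `COc1cc2ncnc(N3CCCc4ccccc43)c2cc1NC(=O)/C=C/CN1CCN(C)CC1` keeps the side chain of compound 2 and instead alters the amine on the core: 1,2,3,4-tetrahydroquinolin-1-yl in place of 2,3-dihydro-1H-indol-1-yl on an aromatic carbon. Among the compounds with values here, none of the measured steps touches this part of the molecule, so no direct guide exists. Without such a guide, the number for compound 4 is expected to stay nearly unchanged a 1.0-fold lower number from compound 2 to compound 4 (0.00 log units; within the scatter). The estimate for compound 4 is 6400 nM, between 2500 nM and 16000 nM.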

Compound 4, half-maximal inhibitory concentration: 8560 nM
Estimate against measurement, compound 4: 1.3-fold (0.13 log units) below; the range from low to high includes it.
By their numbers in this assay, from the lowest: compound 3; then compounds 1, 2 and 4 (each within the scatter of the next).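

In this assay the change from 2,3-dihydro-1H-indol-1-yl to 1,2,3,4-tetrahydroquinolin-1-yl gives a 1.3-fold higher number from compound 2 to compound 4 (0.12 log units; within the scatter) with the side chain held fixed. Within the data shown here, this is the first reading at this place on the core, and it shows that a six-membered non-aromatic ring can stand in for the five-membered one with no change beyond the scatter. Nothing at hand explains this result. Still open, from the compounds shown here alone, is how a non-fused amine such as morpholin-4-yl would read here. Also open, going by these compounds, is whether 1,2,3,4-tetrahydroquinolin-1-yl behaves alike with the side chain of compound 3.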